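The source may hold more compounds than are shown below. What is called first, only, known or untested is meant among the compounds shown, and "the series" means these compounds.

Measured so far in a functional assay on MDA-MB-231 cells (Homo sapiens) for inhibition, read by CCK-8 assay, with a stated time of 48 h; a higher number here means a weaker inhibitor of growth, a lower number a stronger inhibitor of growth:
Compound 1 `CN1CCN(c2ccc(Nc3ncc(Cl)c(Nc4ccccc4)n3)nc2)CC1` gives 37400 nM.
Compound 2 `Cc1ccc(CNc2nc(Nc3ccc(N4CCN(C)CC4)cn3)ncc2Cl)cc1` gives 18600 nM.
Compound 3 `Cc1cccc(Nc2nc(Nc3ccc(N4CCN(C)CC4)cn3)ncc2Cl)c1` gives 5270 nM.

Compound 3 stands lowest of the three numbers in this assay. Its nearest neighbour is compound 2, with the step of a 3.5-fold lower number from compound 2 to compound 3 (0.55 log units; beyond the scatter); its furthest is compound 1, with the step of a 7.1-fold lower number from compound 1 to compound 3 (0.85 log units; beyond the scatter). The step of a 2.0-fold lower number from compound 1 to compound 2 (0.30 log units; within the scatter) sits within the scatter.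

Compound 4 `COc1cccc(Nc2nc(Nc3ccc(N4CCN(C)CC4)cn3)ncc2Cl)c1` differs from compound 3 in one place: methoxy in place of methyl on an aromatic carbon. Among the compounds with values here, no measured step swaps methyl for methoxy anywhere, so nothing bears on this change directly. The only step touching the same aromatic carbon is a 7.1-fold lower number from compound 1 to compound 3 (0.85 log units; beyond the scatter), which shows that a small group there lowered the number; whether a methoxy does the same is not shown. The step of a 1.1-fold higher number from compound 3 to compound 4 (0.06 log units; within the scatter) in this assay is therefore expected to be small, within the scatter, with no direction claimed. Compound 4 is estimated at 6000 nM in this assay, with a range from 2500 nM to 15000 nM.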

Compound 4, concentration for 50% growth inhibition: 8510 nM
Beside the measured number, compound 4's estimate is 1.4-fold (0.15 log units) below it, within the range that was stated.
By their numbers in this assay, from the lowest: compounds 3 and 4 (each within the scatter of the next); then compounds 2 and 1 (each within the scatter of the next).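

In this assay methoxy in place of methyl gives a 1.6-fold higher number from compound 3 to compound 4 (0.21 log units; within the scatter) at this aromatic carbon, meta to a large group, so the two groups are not told apart here. Methoxy in place of hydrogen gives a 4.4-fold lower number from compound 1 to compound 4 (0.64 log units; beyond the scatter) and 3-methoxyphenyl in place of 4-methylbenzyl on the nitrogen gives a 2.2-fold lower number from compound 2 to compound 4 (0.34 log units; beyond the scatter), so both changes that methyl had made beyond the scatter are also beyond it with methoxy, though the oxygen and its hydrogen-bond acceptor bring no separation from methyl. No evidence at hand accounts for these steps.

Open, on these data alone, is whether a different kind of group on this carbon, such as an amine, a carboxylic acid or a longer alkoxy chain, would move the number beyond the scatter from compound 3. Also open, as far as these compounds go, is whether methyl or methoxy on another carbon of this ring would give the same steps.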